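The source may hold more compounds than are shown below. What is called first, only, known or untested is meant among the compounds shown, and "the series" means these compounds.

Three compounds share the same amide-linked nitro-chlorophenyl unit but differ in the ring that carries the amide nitrogen. Compound 1 `O=C(Nc1ccc(F)c(-c2nc3ccccc3s2)c1)c1cc([N+](=O)[O-])ccc1Cl` and compound 2 `O=C(Nc1cccc(-c2nc3ccccc3s2)c1)c1cc([N+](=O)[O-])ccc1Cl` are built on one core, while compound 3 `O=C(Nc1nc(-c2cccc(F)c2)cs1)c1cc([N+](=O)[O-])ccc1Cl` and the as yet unmeasured compound 4 `O=C(Nc1nc(-c2ccc(F)c(F)c2)cs1)c1cc([N+](=O)[O-])ccc1Cl` are built on another; the difference between the two cores is not broken down here.

In an ADME assay for permeability, using PAMPA, at pH 7.4 (on this read-out lower numbers stand for lower permeability and higher numbers for higher permeability), compound 1 gives 17 10^-6 cm/s, compound 2 gives 12 10^-6 cm/s, and compound 3 gives 3 10^-6 cm/s. Compound 3 thus stands lowest of the three, with compound 2 nearest and compound 1 furthest, both gaps lying beyond the usual scatter.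

One structural change appears twice among these compounds. From compound 2 to compound 1 it is fluoro in place of hydrogen on an aromatic carbon, and it made a step of a 1.4-fold higher number from compound 2 to compound 1 (0.15 log units; within the scatter). From compound 3 to compound 4 it is fluoro in place of hydrogen on an aromatic carbon. The two are the same kind of change, though the surroundings differ: in the first case the new fluoro group is ortho to a 1,3-benzothiazol-2-yl group, in the second it is ortho to a fluoro group, in both cases para to a large group.

Because the earlier fluoro step of a 1.4-fold higher number from compound 2 to compound 1 (0.15 log units; within the scatter) stayed within the scatter, compound 4 is expected to sit close to compound 3, with an estimated step of a 1.3-fold higher number from compound 3 to compound 4 (0.12 log units; within the scatter). For compound 4 in this assay the estimated value is 4 10^-6 cm/s, expected to fall between 2 10^-6 cm/s and 8 10^-6 cm/s.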

Compound 4, apparent permeability: 37 10^-6 cm/s
Compound 4: the middle estimate sits 9.3-fold (0.97 log units) below what was measured, and the stated range ends below it.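

In this assay, going from 3-fluorophenyl to 3,4-difluorophenyl made a step of a 12-fold higher number from compound 3 to compound 4 (1.09 log units; beyond the scatter), so one added fluoro group changed the read-out far more here than the same kind of change did on the core of compound 1 and compound 2. Within the data shown here, a hydrogen-to-fluoro change therefore cannot be assumed to carry the same size of step from one core to the other, as the two measured steps disagree: the same change on two cores in this assay, a 1.4-fold higher number (0.15 log units; within the scatter) from compound 2 to compound 1 and a 12-fold higher number (1.09 log units; beyond the scatter) from compound 3 to compound 4, 8.7-fold (0.94 log units) apart, beyond the scatter of two such steps This result rests on only one pair of compounds for each core, so it shows that the two steps differ, but not why they differ, and it gives no rule for predicting the step when fluoro is added elsewhere on either core.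

The compounds shown leave open whether the large step needs the first fluoro group already in place, or whether a single fluoro group in the new position on an otherwise unsubstituted phenyl ring would give it too. They also leave open whether a chloro, methyl or methoxy group in that same place would give a step like that of fluoro.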